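Shortening the amine substituent on the shared core

This account rests on a few compounds, and the source may have more. Where it says the series, first, only, none or still open, it means among the compounds named here.

Compound 1 `CC(C(=O)NCc1ccc(C(F)(F)F)nc1NC1CCCCC1)c1ccc(NS(C)(=O)=O)c(F)c1`: 20.4 nM
Compound 2 `Cc1ccc(Nc2nc(C(F)(F)F)ccc2CNC(=O)C(C)c2ccc(NS(C)(=O)=O)c(F)c2)cc1C`: 39.3 nM
Compound 3 `CC(C(=O)NCc1ccc(C(F)(F)F)nc1N1CCC(c2ccccc2)CC1)c1ccc(NS(C)(=O)=O)c(F)c1`: 0.6 nM

Of the compounds shown here, three have been measured in a functional assay on CHO-K1 cells for antagonist activity at transient receptor potential cation channel subfamily V member 1 (Homo sapiens), read by FLIPR; a higher number here means a weaker inhibitor, a lower number a stronger inhibitor. Compound 3 stands lowest of the three, with the nearest neighbour being compound 1 a 34-fold lower number from compound 1 to compound 3 (1.53 log units; beyond the scatter) and the furthest being compound 2 a 66-fold lower number from compound 2 to compound 3 (1.82 log units; beyond the scatter). The step between compound 1 and compound 2 is small a 1.9-fold higher number from compound 1 to compound 2 (0.28 log units; within the scatter).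

Compound 4 `CC(C(=O)NCc1ccc(C(F)(F)F)nc1N1CCCCCCC1)c1ccc(NS(C)(=O)=O)c(F)c1` has not yet been measured. It differs from compound 3 in one place (a group of 8 heavy atoms (7 carbon, 1 nitrogen; one eight-membered non-aromatic ring with 1 hetero atom) in place of a group of 12 heavy atoms (11 carbon, 1 nitrogen; one six-membered non-aromatic ring with 1 hetero atom, one six-membered aromatic ring of carbon only), on an aromatic carbon). The change removes the six-membered aromatic ring of carbon only and replaces the six-membered non-aromatic ring with an eight-membered non-aromatic ring on the same aromatic carbon.

Among the measured compounds shown here, the step that bears most directly on this is the one from compound 1 to compound 3, where a cyclohexylamino group gave way to 4-phenylpiperidin-1-yl a 34-fold lower number from compound 1 to compound 3 (1.53 log units; beyond the scatter). Compound 4, like compound 1, carries a saturated ring and no aromatic ring at this position, so a step back toward the number of compound 1 is expected. For compound 4 the estimated step is a 13-fold higher number from compound 3 to compound 4 (1.12 log units; beyond the scatter). Compound 4 is therefore estimated at 8 nM, with a range from 2 nM to 40 nM.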

Compound 4, inhibition constant: 0.7 nM
Compound 4: middle estimate off by 11-fold (1.06 log units), on the high side; the whole stated range lies above it.
By their numbers in this assay, from the lowest: compounds 3 and 4 (each within the scatter of the next); then compounds 1 and 2 (each within the scatter of the next).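

In this assay, the eight-membered ring of compound 4 matches 4-phenylpiperidin-1-yl within the scatter (a 1.2-fold higher number from compound 3 to compound 4 (0.07 log units; within the scatter)), so the low number at this aromatic carbon does not depend on the six-membered aromatic ring that compound 3 carries. Compound 4 also stands well apart from the two amino-linked compounds, both from the aryl group (a 56-fold lower number from compound 2 to compound 4 (1.75 log units; beyond the scatter)) and from the saturated cyclohexyl group (a 29-fold lower number from compound 1 to compound 4 (1.46 log units; beyond the scatter)), so a saturated ring with no aromatic ring does not by itself bring the number back toward that of compound 1. Across these four compounds, the two low numbers belong to the groups whose nitrogen on the aromatic carbon is a ring member, and neither of the other two goes against this; nothing available here explains the pattern.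

Whether ring membership of that nitrogen or the size of the ring matters more stays open, since the shared core is shown here with only a six-membered and an eight-membered ring in that role. Pyrrolidin-1-yl, piperidin-1-yl and methyl(cyclohexyl)amino groups at this position would help separate these two features.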